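This account rests on a few compounds, and the source may have more. Where it says the series, first, only, none or still open, it means among the compounds named here.

Measured so far in a functional assay on BGC-823 cells (Homo sapiens) for inhibition, read by MTT assay, with a stated time of 72 h; a higher number here means a weaker inhibitor, a lower number a stronger inhibitor:
- compound 1, `Cc1cc(N2CC[C@@H](C)[C@@H](N(C)c3ncnc4[nH]ccc34)C2)n2nc(SCc3cc(Cl)ccc3Cl)nc2n1`: 18900 nM
- compound 2, `Cc1cc(N2CC[C@@H](C)[C@@H](N(C)c3ncnc4[nH]ccc34)C2)n2nc(SCc3ccccc3)nc2n1`: 14400 nM
- compound 3, `COc1ccc(CSc2nc3nc(C)cc(N4CC[C@@H](C)[C@@H](N(C)c5ncnc6[nH]ccc56)C4)n3n2)cc1`: 69900 nM

Compound 3 stands at the highest number of the three, with compound 1 nearest and compound 2 furthest. Compound 4, `Cc1cc(N2CC[C@@H](C)[C@@H](N(C)c3ncnc4[nH]ccc34)C2)n2nc(SCc3csc4ccc(Cl)cc34)nc2n1`, is not yet measured. It differs from compound 3 in one place: 5-chloro-1-benzothiophen-3-yl in place of 4-methoxyphenyl on a saturated chain carbon bound to a sulfur.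

Within the data shown here, two measured steps bear on this change, both replacing the 4-methoxyphenyl: a 3.7-fold higher number from compound 1 to compound 3 (0.57 log units; beyond the scatter) and a 4.9-fold higher number from compound 2 to compound 3 (0.69 log units; beyond the scatter). Read backwards, leaving the 4-methoxyphenyl gave a modest lower number in both cases, and the step of a 1.3-fold lower number from compound 1 to compound 2 (0.12 log units; within the scatter) shows that phenyl and 2,5-dichlorophenyl sit together. Compound 4 is therefore expected to move down by roughly a 4.1-fold lower number from compound 3 to compound 4 (0.61 log units; beyond the scatter), landing near compound 1. Estimated value for compound 4: 17000 nM, range 7000 nM to 40000 nM.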

Compound 4, half-maximal inhibitory concentration: > 100000 nM
Compound 4 was reported as a limit; the forecaster's own chance of this, stated with the estimate: 5%; middle value at least 5.8-fold (0.76 log units) away from the limit.
By their numbers in this assay, from the lowest: compounds 2 and 1 (each within the scatter of the next); then compound 3. At a limit, above all of these: compound 4.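

In this assay compound 4 is reported only as a limit, not a number: the limit of > 100000 nM in this assay, at which 1 of the 4 values shown sits.

The aromatic group at this position does matter: an at least 6.9-fold higher number from compound 2 to compound 4 (0.84 log units; beyond the scatter) and an at least 5.2-fold higher number from compound 1 to compound 4 (0.72 log units; beyond the scatter) both clear the scatter, while an at least 1.4-fold higher number from compound 3 to compound 4 (0.15 log units; that floor lies within the scatter) sets no firm gap to the 4-methoxyphenyl. Leaving the 4-methoxyphenyl therefore does not by itself lower the number; the entering group decides.

Still open, on these data alone, is whether the fused ring, its sulfur or its chlorine accounts for the change. Also open, as far as these compounds go, is how an amine, a carboxylic acid or a longer chain on the saturated chain carbon bound to a sulfur would read.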